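Sulfonamide series: chain extension on the aryl ether carbon

This account rests on a few compounds, and the source may have more. Where it says the series, first, only, none or still open, it means among the compounds named here.

Measured so far:
compound 1 `CC(=O)SCC(=O)c1ccc(NS(=O)(=O)c2ccc(OCCCO)cc2)nc1`, 8600 nM
compound 2 `COc1ccc(S(=O)(=O)Nc2ccc(C(=O)CSC(C)=O)cn2)cc1`, 540 nM
compound 3 `COc1cccc(S(=O)(=O)Nc2ccc(C(=O)CSC(C)=O)cn2)c1`, 4300 nM

In a functional assay on HCT-116 cells (Homo sapiens) for cytotoxicity (a lower number here means that less compound is needed, a higher number that more compound is needed for the effect), compound 2 gives the lowest number of the three; the nearest neighbour is reached by an 8.0-fold higher number from compound 2 to compound 3 (0.90 log units; beyond the scatter), the furthest by a 16-fold lower number from compound 1 to compound 2 (1.20 log units; beyond the scatter) read in reverse. Compound 4 `CC(=O)SCC(=O)c1ccc(NS(=O)(=O)c2ccc(OCCCN3CCCCC3)cc2)nc1` differs from compound 2 by 2-(piperidin-1-yl)ethyl in place of hydrogen on a saturated chain carbon bound to an oxygen on an aromatic ring. Going by the values given here, the one measured step that bears on this place is a 16-fold lower number from compound 1 to compound 2 (1.20 log units; beyond the scatter), where taking a chain off the same saturated chain carbon lowered the number strongly; compound 4 puts a longer chain back there. Among the compounds with values here, a step upward is therefore expected, roughly a 7.4-fold higher number from compound 2 to compound 4 (0.87 log units; beyond the scatter), though no measured pair carries this particular chain. Compound 4 is estimated at 4000 nM, with a range of 1000 nM to 20000 nM.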

Compound 4, half-maximal effective concentration: 1000 nM
The estimate for compound 4 lay 4.0-fold (0.60 log units) above the measured number; measured number inside the range.
By their numbers in this assay, from the lowest: compounds 2 and 4 (each within the scatter of the next); then compounds 3 and 1 (each within the scatter of the next).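

In this assay, the step of a 1.9-fold higher number from compound 2 to compound 4 (0.27 log units; within the scatter) shows that a long chain on the saturated chain carbon bound to the aromatic ether oxygen can be carried without a step beyond the scatter. What stands at the chain end matters here: piperidin-1-yl in place of hydroxy gives an 8.6-fold lower number from compound 1 to compound 4 (0.93 log units; beyond the scatter) on the otherwise identical compound pair. No evidence on the cause of this is available.

Going by these compounds, whether any amine at the chain end would do the same remains open. A morpholine or dimethylamino end group, a carboxylic acid, or a shorter or longer chain carrying piperidin-1-yl would test this.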